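The source may hold more compounds than are shown below. What is called first, only, known or untested is meant among the compounds shown, and "the series" means these compounds.

Working notes on the series. In an assay on CHO-K1 cells for displacement of a labelled ligand from prostaglandin D2 receptor 2 (Homo sapiens), read by scintillation counting and GTPgammaS binding, with a stated time of 1 h (a lower number here means a stronger inhibitor, a higher number a weaker inhibitor), compound 1 `Cc1c(Cc2ccccc2S(=O)(=O)c2ccccc2)c(=O)n(-c2ccccc2)n1CC(=O)O` gives 970 nM, and compound 2 `O=C(O)Cc1ccc(=O)n(Cc2ccccc2S(=O)(=O)c2ccccc2)c1` gives 10000 nM. Compound 3 `Cc1c(Cc2ccccc2S(=O)(=O)c2ccc(F)cc2)c2c(n1CC(=O)O)CCCC2=O` gives 2 nM, the lowest number of the three, and its gaps to compound 1 and to compound 2 both lie beyond the scatter. Compound 4 `COc1ccc(S(=O)(=O)c2ccc(F)cc2)c(Cc2c3c(n(CC(=O)O)c2C)CCCC3=O)c1` has not yet been measured in this assay. It differs from compound 3 in one place: methoxy in place of hydrogen on an aromatic carbon. Among the compounds with values here, no step between two measured compounds matches this change, so no size can be read from the set. The step is expected to stay within the scatter, with no clear direction: a 1.5-fold higher number from compound 3 to compound 4 (0.18 log units; within the scatter). Compound 4 is therefore estimated to give 3 nM in this assay, with a range from 0.8 nM to 12 nM.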

Compound 4, half-maximal inhibitory concentration: 2 nM
For compound 4 the middle estimate is 1.5-fold (0.18 log units) above the measured one, and the stated range covers the measured number.
By their numbers in this assay, from the lowest: compounds 3 and 4 (each within the scatter of the next); then compound 1; then compound 2.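

Within the data shown here, the earlier compounds carry only hydrogen on this aromatic carbon, para to a (4-fluorophenyl)sulfonyl group, so this is the first reading of a substituent there. In this assay, methoxy in place of hydrogen gives no change at the digits printed from compound 3 to compound 4 (within the scatter), so this carbon accepts methoxy without a shift in the number. Nothing on hand bears on why the number holds.

Open, from the compounds shown here alone, is whether a hydroxyl, an amine or a longer chain such as ethoxy on this carbon would leave the number in place. Also open, going by these compounds, is whether methoxy on the other carbons of this ring would do the same.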